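This account rests on a few compounds, and the source may have more. Where it says the series, first, only, none or still open, it means among the compounds named here.

Of the compounds shown here, three have been measured in a functional assay on CCRF-CEM cells (Homo sapiens) for inhibition, read by MTT assay, with a stated time of 2 days, tested at 10 uM; on this read-out lower numbers stand for less inhibition and higher numbers for more inhibition at the one concentration tested (going by the name of the read-out). In this assay compound 1 `COc1ccc(-c2cn(-c3ccc(O)c(C(=O)O)c3)nn2)cc1` gives 9%, compound 2 `COC(=O)c1cc(-n2cc(-c3ccc(OC)cc3)nn2)ccc1O` gives 16%, and compound 3 `COC(=O)c1cc(-n2cc(-c3cccc(O)c3)nn2)ccc1O` gives 5%; compound 1 and compound 3 lie within the scatter of each other. Compound 4 `O=C(O)c1cc(-n2cc(-c3cccc(O)c3)nn2)ccc1O` has not yet been measured in this assay.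

Compound 4 is obtained from compound 3 by a single change, (hydrogen in place of methyl on an oxygen next to a carbonyl group). The same change, at the same place, links compound 2 to compound 1, (hydrogen in place of methyl on an oxygen next to a carbonyl group), and there it made a number 7 percentage points lower from compound 2 to compound 1 (within the scatter). The two cores on which this change is made are not identical: 3-hydroxyphenyl in place of 4-methoxyphenyl on an aromatic carbon, a change that on its own made a number 11 percentage points lower from compound 2 to compound 3 (beyond the scatter).

Because the earlier step made a number 7 percentage points lower from compound 2 to compound 1 (within the scatter), the step from compound 3 to compound 4 is expected to be small as well, about a number 2 percentage points lower from compound 3 to compound 4 (within the scatter). Compound 4 is therefore estimated to give 3% in this assay, most likely between -5% and 12%, because compound 3 itself gives 5%.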

Compound 4, a percentage reported as inhibition, at one concentration (the size of the read-out at that concentration, not a potency): 3%
Compound 4: middle estimate and measured number agree at the digits printed; low and high end bracket the measured number.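

Replacing the methyl on the oxygen next to the carbonyl group with hydrogen, which turns methoxycarbonyl into carboxy, made a number 2 percentage points lower from compound 3 to compound 4 (within the scatter) in this assay. Set beside the earlier case, the change gives the same picture on both cores, so within this small set it can be carried from one core to the other without a visible difference: the same change on two cores in this assay, a number 7 percentage points lower (within the scatter) from compound 2 to compound 1 and a number 2 percentage points lower (within the scatter) from compound 3 to compound 4, 5 percentage points apart, within the scatter of two such steps

Among the compounds shown here, this shows only that the change left no step beyond the scatter on these two cores at the one concentration tested; it does not show that the change would stay as small on other cores, or that the two cores respond identically, since differences smaller than the scatter cannot be seen.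

The compounds shown leave open whether an amide or an ethyl ester in place of the methoxycarbonyl group would give a step beyond the scatter. They also leave open what an amine in place of the hydroxy on the 3-hydroxyphenyl group would do.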